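This account rests on a few compounds, and the source may have more. Where it says the series, first, only, none or still open, it means among the compounds named here.

In a functional assay on MIA PaCa-2 cells (Homo sapiens) for inhibition, read by MTT assay, with a stated time of 3 days (a lower number here means a stronger inhibitor, a higher number a weaker inhibitor), compound 1 `CCN(CC)S(=O)(=O)c1ccc(S(=O)(=O)N2CCC[C@@H](C(=O)N3CCC(O)CC3)C2)cc1` gives 230 nM and compound 2 `CCN(CC)S(=O)(=O)c1ccc(S(=O)(=O)N2CCC[C@@H](C(=O)N3CCC(F)(F)CC3)C2)cc1` gives 19 nM, the lower of the two numbers shown. Within the data shown here, the one step known, a 12-fold lower number from compound 1 to compound 2 (1.08 log units; beyond the scatter), is the only guide. Compound 3 `CCN(CC)S(=O)(=O)c1ccc(S(=O)(=O)N2CCC[C@@H](C(=O)N3CC[C@@H](OC)C3)C2)cc1` differs from compound 2 by 3-methoxypyrrolidin-1-yl in place of 4,4-difluoropiperidin-1-yl on a carbonyl carbon. Because a 12-fold lower number from compound 1 to compound 2 (1.08 log units; beyond the scatter) ran from a ring bearing an oxygen to one bearing two fluorines, the return to an oxygen-bearing ring in compound 3 is expected to move the number back up, though the methoxy group carries no donor. Compound 3 is therefore estimated at 80 nM, within 25 nM to 300 nM, a step of a 4.2-fold higher number from compound 2 to compound 3 (0.62 log units; beyond the scatter).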

Compound 3, half-maximal inhibitory concentration: 1070 nM
Estimate against measurement, compound 3: 13-fold (1.13 log units) below; the whole stated range lies below it.
By their numbers in this assay, from the lowest: compound 2; then compound 1; then compound 3.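

In this assay, this position on a carbonyl carbon proves able to raise the number as well as lower it: a 56-fold higher number from compound 2 to compound 3 (1.75 log units; beyond the scatter) and, against the hydroxy compound, a 4.7-fold higher number from compound 1 to compound 3 (0.67 log units; beyond the scatter). An oxygen-bearing ring therefore does not fix the number at one level, and compound 3 changes both ring size and substituent in a single step. No evidence given here accounts for these steps. Going by these compounds, whether the five-membered ring or the methoxy group drives the rise stays open. So do the readings of 4-methoxypiperidin-1-yl, 3,3-difluoropyrrolidin-1-yl and the opposite stereoisomer of 3-methoxypyrrolidin-1-yl.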